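The compounds below may be only part of what the source reports. "The series", "measured", "known", "first", "only" and "open" are said of these compounds alone.

Working notes on the series. Compound 1 `CCCSc1nc(Cl)c2c(n1)N(CC1CCCCC1)C(C(=O)N1CCN(C)CC1)N2` is measured in a functional assay on MGC-803 cells (Homo sapiens) for antiproliferative activity, read by MTT assay, with a stated time of 72 h; on this read-out lower numbers stand for stronger inhibition and higher numbers for weaker inhibition. For compound 1 only a limit of the assay is reported, > 64000 nM. Compound 2 `CCCSc1nc(Cl)c2c(n1)N(CCNC(=O)OC(C)(C)C)C(C(=O)N1CCN(C)CC1)N2` differs from it at one place and in this assay compound 2 gives 59300 nM. The step of an at least 1.0-fold lower number from compound 1 to compound 2 (0.03 log units; that floor lies within the scatter) is read against a limit, so its floor says nothing beyond the scatter. On the numbers shown compound 2 holds the only number; the remaining value is a limit, namely (the limit of > 64000 nM in this assay, at which 1 of the 2 values shown sits).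

Compound 3 `CCCSc1nc(Cl)c2c(n1)N(Cc1ccco1)C(C(=O)N1CCN(C)CC1)N2` is not yet measured in this assay. The change from compound 2 is furan-2-yl in place of ((tert-butoxycarbonyl)amino)methyl on a saturated chain carbon bound to a nitrogen on an aromatic ring in a ring. Among the measured compounds shown here, the only measured step at this place is the one from compound 1 to compound 2, whose size, an at least 1.0-fold lower number from compound 1 to compound 2 (0.03 log units; that floor lies within the scatter), is bounded by the limit of > 64000 nM in this assay, at which 1 of the 2 values shown sits, and lies within the scatter. On that basis no step beyond the scatter is expected from compound 2 to compound 3 in this assay, that is an expected step of a 1.2-fold lower number from compound 2 to compound 3 (0.07 log units; within the scatter). Compound 3 is therefore estimated at 50000 nM, with a range from 15000 nM to 150000 nM, and a limit rather than a number is a real possibility.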

Compound 3, half-maximal inhibitory concentration: 53800 nM
The estimate for compound 3 lay 1.1-fold (0.03 log units) below the measured number, within the range that was stated.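

Among the compounds shown here, replacing ((tert-butoxycarbonyl)amino)methyl with furan-2-yl on a saturated chain carbon bound to a nitrogen on an aromatic ring in a ring gives, in this assay, a 1.1-fold lower number from compound 2 to compound 3 (0.04 log units; within the scatter), the first step at this place with a measured number at both ends. The change swaps an open chain carrying a hydrogen-bond donor for a five-membered aromatic ring without one, and compound 2 and compound 3 remain within the scatter of each other, so in this pair neither the loss of that donor nor the entry of the ring separates the two values. The other new step, an at least 1.1-fold lower number from compound 1 to compound 3 (0.07 log units; that floor lies within the scatter), is read against a limit of the assay and adds nothing further: the limit of > 64000 nM in this assay, at which 1 of the 3 values shown sits.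

The compounds shown leave open whether any group at this place can move the number beyond the scatter, for example a free primary amine, a carboxylic acid or a longer chain. They also cannot tell whether the same lack of separation between furan-2-yl and ((tert-butoxycarbonyl)amino)methyl would hold with a different group elsewhere on the shared core.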